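The source may report more compounds than this note shows. Statements on the series, on what has been measured and on what is new or still open speak of the compounds shown alone.

Three compounds have so far been characterized in an ADME assay on MT2 cells (Homo sapiens) for cytotoxicity; a higher number here means that more compound is tolerated, a lower number that less compound is tolerated. Compound 1, `CC(C)=CCOc1cc(Nc2ncnc(Cl)n2)ccc1Cl`, gives 45000 nM. Compound 2, `CC(C)=CCOc1cc(Nc2nc(C)nc(Cl)n2)ccc1Cl`, gives 40000 nM. The change from compound 1 to compound 2 is methyl in place of hydrogen on an aromatic carbon and it produced a 1.1-fold lower number from compound 1 to compound 2 (0.05 log units; within the scatter). Compound 3, `COc1ccnc(Nc2ccc(Cl)c(Oc3ccccc3)c2)n1`, rests on a different core; the difference between the two cores is not broken down here. In this assay compound 3 gives 38000 nM, and this value and those of compound 1 and compound 2 all lie within the scatter of one another, so none of the three can be set apart from the others.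

Compound 4, `COc1ccnc(Nc2ccc(Cl)c(Oc3ccccc3C)c2)n1`, has not yet been measured. It differs from compound 3 by methyl in place of hydrogen on an aromatic carbon. Among the compounds with values here, this is the same kind of change as the one from compound 1 to compound 2, but not the same: in compound 2 the methyl sits on a six-membered aromatic ring with 3 nitrogen, between two ring nitrogen atoms, meta to a chloro group, meta to a large group and opposite the ring nitrogen, whereas in compound 4 it sits on a six-membered aromatic ring of carbon only, ortho to a large group. Within the data shown here, the one measured instance of this kind of change, from compound 1 to compound 2, stayed within the scatter. On that basis the author expects a 1.1-fold lower number from compound 3 to compound 4 (0.04 log units; within the scatter), much like the earlier step. Compound 4 is therefore estimated to give 35000 nM in this assay, with a likely range from 20000 nM to 60000 nM.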

Compound 4, half-maximal cytotoxic concentration: 13000 nM
The estimate for compound 4 lay 2.7-fold (0.43 log units) above the measured number; measured number below the stated range.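

In this assay, within the data shown here, methyl in place of hydrogen on the six-membered aromatic ring of carbon only, ortho to a large group, gives a 2.9-fold lower number from compound 3 to compound 4 (0.47 log units; beyond the scatter) and so is the one step that clears the scatter. Although the earlier step stayed within the scatter and this one did not, the gap between them is itself too small to separate the two instances of this change: the same change on two cores in this assay, a 1.1-fold lower number (0.05 log units; within the scatter) from compound 1 to compound 2 and a 2.9-fold lower number (0.47 log units; beyond the scatter) from compound 3 to compound 4, 2.6-fold (0.41 log units) apart, within the scatter of two such steps. Among these compounds, the result therefore does not show that the core decides what this change does, nor does it show that the change carries over unchanged from one core to another, and with only two pairs, in which the methyl also sits on different rings, the effect of the core cannot be separated from that of the methyl's place.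

The compounds shown leave open whether the lower number on the core of compound 3 is specific to methyl or would also follow from an ethyl, methoxy or chloro group in the same place. They also leave open what a methyl would do elsewhere on the phenoxy ring, and whether a third core would give a step closer to the first or to the second.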